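Cyclobutyl for Ethyl on Two Cores, Cell Tolerance

The compounds below may be only part of what the source reports. "The series", "measured", "known", "first", "only" and "open" are said of these compounds alone.

Of the compounds shown here, three have been measured in an ADME assay on Vero cells (Chlorocebus sabaeus) for cytotoxicity, read by CellTiter-Glo, with a stated time of 72 h; a lower number here means that less compound is tolerated, a higher number that more compound is tolerated. Compound 1 `CCNc1n[n+]([O-])c2cc(Cl)ccc2[n+]1[O-]` gives 2.6 ug/mL. Compound 2 `[O-][n+]1nc(NC2CCC2)[n+]([O-])c2ccc(Cl)cc21` gives 1.6 ug/mL. Compound 3 `CCNc1n[n+]([O-])c2cc(C)c(OC)cc2[n+]1[O-]` gives only a limit of the assay, > 100 ug/mL.

Compound 1 and compound 2 share one core and differ by cyclobutyl in place of ethyl on a nitrogen on an aromatic ring. That change produced a 1.6-fold lower number from compound 1 to compound 2 (0.21 log units; within the scatter). Compound 3 sits on a different core; the difference between the two cores is not broken down here. Its value is a limit rather than a number, and such a limit is the limit of > 100 ug/mL in this assay, at which 1 of the 3 values shown sits.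

Compound 4 `COc1cc2c(cc1C)[n+]([O-])nc(NC1CCC1)[n+]2[O-]` has not yet been measured. It differs from compound 3 by cyclobutyl in place of ethyl on a nitrogen on an aromatic ring, the same change as between compound 1 and compound 2, at the same place. Because a 1.6-fold lower number from compound 1 to compound 2 (0.21 log units; within the scatter) stayed within the scatter, the matching step on the core of compound 3 is expected to be small as well. Compound 4 is expected to show a step of a number no higher from compound 3 to compound 4 (the limit leaves the size open) and thus a value near 100 ug/mL, most likely reported again only as a limit. The estimated span for compound 4 runs from 30 ug/mL to 300 ug/mL.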

Compound 4, half-maximal cytotoxic concentration: > 50 ug/mL
Compound 4: a limit, no number; the forecaster's own chance of this, stated with the estimate: 70%; the middle value lies beyond the limit too.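

Among the compounds shown here, compound 3 and compound 4 are both reported in this assay only as limits of the assay, not as numbers, and no step between them can be read. The compounds shown leave open whether cyclobutyl in place of ethyl changes cell tolerance on the core of compound 3 as little as it does on the core of compound 1.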